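Notes on a 4-hydroxyphenyl replacement in compound 1

This account rests on a few compounds, and the source may have more. Where it says the series, first, only, none or still open, it means among the compounds named here.

Of the compounds shown here, two with the same core have values so far. In a functional assay on ECa-109 cells (Homo sapiens) for cytotoxicity, read by MTT assay, with a stated time of 72 h (a lower number here means a stronger inhibitor, a higher number a weaker inhibitor), compound 1 `CC(C)=C1C(=O)N(c2ccc(Cl)cc2)N(c2ccc(Cl)cc2)C1=O` gives 42100 nM, and compound 2 `O=C1C(=Cc2ccc(F)cc2)C(=O)N(c2ccc(Cl)cc2)N1c1ccc(Cl)cc1` gives 35600 nM. These two values lie within the scatter of each other, so compound 1 stands level with compound 2.

Compound 3 `CC(=C1C(=O)N(c2ccc(Cl)cc2)N(c2ccc(Cl)cc2)C1=O)c1ccc(O)cc1` has not yet been measured. Its difference from compound 1 is 4-hydroxyphenyl in place of methyl on a double-bonded chain carbon bound to a double-bonded ring carbon and a saturated chain carbon, which in words is 4-hydroxyphenyl in place of methyl on a double-bonded chain carbon bound to a double-bonded ring carbon and a saturated chain carbon.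

For the measured compounds named here, no measured pair isolates this change, so the series offers no direct guide to its size or direction. With compound 2 at 35600 nM as the only other reference point, no step beyond the scatter is expected in this assay, with only a slight lean towards a lower number. The estimated change is a 1.7-fold lower number from compound 1 to compound 3 (0.23 log units; within the scatter). For compound 3 the estimated value is 25000 nM, with an expected range of 8000 nM to 70000 nM.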

Compound 3, half-maximal inhibitory concentration: 55600 nM
Compound 3: middle estimate off by 2.2-fold (0.35 log units), on the low side; measured number inside the range.
By their numbers in this assay, from the lowest: compounds 2, 1 and 3 (each within the scatter of the next).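

In this assay, for the compounds shown here, 4-hydroxyphenyl in place of methyl on a double-bonded chain carbon bound to a double-bonded ring carbon and a saturated chain carbon gives a 1.3-fold higher number from compound 1 to compound 3 (0.12 log units; within the scatter), the first direct reading of any change at this position. The position therefore accepts an aromatic ring carrying a hydroxyl without a step beyond the scatter, with compound 3 at 55600 nM and compound 1 at 42100 nM standing level in this assay. No measurement of any other kind bears on this result.

Still open, from the compounds shown here alone, is whether the ring and the hydroxyl each have any effect of their own, or whether the two happen to offset each other; an unsubstituted phenyl at this carbon would separate them, and a 4-aminophenyl or 4-carboxyphenyl would test other groups on the same ring. Going by these compounds, it is also open whether any replacement at this carbon, such as a longer alkyl chain or a basic amine on a chain, can move the number beyond the scatter at all.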